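The compounds below may be only part of what the source reports. "The series", "measured", "known", "first", "only" and "open" are said of these compounds alone.

Measured compounds:
compound 1, `CN(C)C(=O)c1cc2cnc(Nc3ccc(NC(=O)C4(C(=O)Nc5ccccc5)CC4)cc3)nc2n1C1CCCC1`: 42.4%
compound 2, `CN(C)C(=O)c1cc2cnc(Nc3ccc(NC(=O)C4(C(=O)Nc5ccccc5F)CC4)cc3)nc2n1C1CCCC1`: 28.2%
compound 3, `CN(C)C(=O)c1cc2cnc(Nc3ccc(NC(=O)C4(C(=O)Nc5ccc(Br)cc5)CC4)cc3)nc2n1C1CCCC1`: 31.5%

The three were run in a functional assay on NCI-H460 cells (Homo sapiens) for inhibition, read by CCK-8 assay, with a stated time of 72 h, tested at 1 uM; a lower number here means less inhibition of growth, a higher number more inhibition of growth at the concentration tested. Compound 1 stands highest of the three numbers; the nearest is compound 3, the furthest compound 2, and both gaps lie beyond the scatter. Compound 2 and compound 3 lie within the scatter of each other, as a number 3.3 percentage points higher from compound 2 to compound 3 (within the scatter) shows.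

Compound 4 is `CN(C)C(=O)c1cc2cnc(Nc3ccc(NC(=O)C4(C(=O)Nc5ccc(Cl)c(C(F)(F)F)c5)CC4)cc3)nc2n1C1CCCC1`, not yet measured in this assay. Against compound 1 the change is 4-chloro-3-(trifluoromethyl)phenyl in place of phenyl on an amide-type nitrogen, so two substituents enter on the phenyl that is bare in compound 1.

Within the data shown here, two measured steps bear on this. Putting fluoro in place of hydrogen on an aromatic carbon of that phenyl gave a number 14.2 percentage points lower from compound 1 to compound 2 (beyond the scatter), and bromo in place of hydrogen gave a number 10.9 percentage points lower from compound 1 to compound 3 (beyond the scatter); both lowered the number by a modest amount beyond the scatter. Nothing measured here carries either chloro or trifluoromethyl on that ring, so the expectation rests on these two steps alone, and a step of the same kind is expected: lower, modest, beyond the scatter, as a number 13.4 percentage points lower from compound 1 to compound 4 (beyond the scatter).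

For compound 4 the estimate in this assay is therefore 29%, expected to fall between 15% and 43%.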

Compound 4, percent growth inhibition at one concentration: 2.1%
Estimate against measurement, compound 4: 26.9 percentage points above; the measured number lies below the stated range.
By their numbers in this assay, from the lowest: compound 4; then compounds 2 and 3 (each within the scatter of the next); then compound 1.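

In this assay, among these compounds, the 4-chloro-3-(trifluoromethyl)phenyl group on the amide-type nitrogen gives the first large step at this position, a number 40.3 percentage points lower from compound 1 to compound 4 (beyond the scatter), so changes to this phenyl can remove nearly all of the growth inhibition seen at the concentration tested, not merely trim it as the single fluoro and bromo changes did. Among the compounds shown here, compound 4 also separates from both singly halogenated compounds, with a number 29.4 percentage points lower from compound 3 to compound 4 (beyond the scatter) and a number 26.1 percentage points lower from compound 2 to compound 4 (beyond the scatter), which leaves the unsubstituted phenyl of compound 1 highest and no compound among the four going against the fall on substitution of this ring. No measurement at hand accounts for the size of this drop.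

Compound 4 carries chloro and trifluoromethyl together, so the share of each in the step stays unresolved, and so does whether either group alone would give a drop of this size. Also open, going by these compounds, is whether a carboxylic acid or an aminomethyl group on this phenyl, or a cyclohexyl ring in its place, would keep the number near that of compound 1 or lower it as well.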